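The compounds below may be only part of what the source reports. "The series", "measured", "known", "first", "only" and "open" are said of these compounds alone.

Measured compounds:
compound 1 `Cc1c(OCCCCOc2ccc(C(=O)O)cc2Cl)ccc(C(=O)CC2CCCC2)c1O`: 82.2%
compound 2 `Cc1c(OCCCCOc2ccc(C(=O)O)cc2F)ccc(C(=O)CC2CCCC2)c1O`: 83.8%
compound 3 `Cc1ccc(C(=O)O)cc1OCCCCOc1ccc(C(=O)CC2CCCC2)c(O)c1C`: 67.5%

In an assay on HEK293 cells for positive allosteric modulation of metabotropic glutamate receptor 2 (Rattus norvegicus), read by thallium flux, with a stated time of 2.5 min (on this read-out higher numbers stand for larger maximal responses and lower numbers for smaller maximal responses), compound 1 stands second highest of the three. Compound 2 sits within the scatter of it (a number 1.6 percentage points higher from compound 1 to compound 2 (within the scatter)), while compound 3 lies beyond the scatter below it (a number 14.7 percentage points lower from compound 1 to compound 3 (beyond the scatter)).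

Compound 4 `Cc1c(OCCCCOc2ccc(C(=O)O)cc2Cl)ccc(C(=O)CC(C)C)c1O` differs from compound 1 by isopropyl in place of cyclopentyl on a saturated chain carbon bound to a carbonyl carbon. For the measured compounds named here, none of the measured steps touches this part of the molecule: a number 1.6 percentage points higher from compound 1 to compound 2 (within the scatter) and a number 16.3 percentage points lower from compound 2 to compound 3 (beyond the scatter) both concern the carboxyphenyl end, and the (cyclopentylmethyl)carbonyl is unchanged across compounds 1 to 3. Going by the values given here, with no comparable step in hand, no change beyond the scatter is expected in this assay, and compound 4 is estimated at 79% (range 64% to 92%), an expected step of a number 3.2 percentage points lower from compound 1 to compound 4 (within the scatter).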

Compound 4, largest response reached (reported as percent of maximum), in percent of the reference or control that the assay uses: 99.5%
The estimate for compound 4 lay 20.5 percentage points below the measured number; measured number above the stated range.
By their numbers in this assay, from the lowest: compound 3; then compounds 1 and 2 (each within the scatter of the next); then compound 4.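

The group on the saturated chain carbon bound to a carbonyl carbon does shift the maximal response: in this assay, isopropyl in place of cyclopentyl gives a number 17.3 percentage points higher from compound 1 to compound 4 (beyond the scatter) at this position. This end of the molecule, unchanged from compound 1 through compound 3, therefore also moves the read-out, and here the open-chain group with fewer heavy atoms gives the higher number. No measurement shown bears on the cause of this step.

One pair cannot separate loss of the ring from loss of heavy atoms; a cyclopropyl, a tert-butyl or a longer chain at this place would help. From the compounds shown here alone, whether the step carries over to the fluoro analogue, compound 2, remains open.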